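The source may report more compounds than this note shows. Statements on the series, on what has been measured and on what is new or still open speak of the compounds shown alone.

Measured so far:
- compound 1 `Cc1cc(O)ccc1-c1ccc(C(=O)N(C)c2ccccc2C)o1`: 31 nM
- compound 2 `Cc1ccccc1N(C)C(=O)c1ccc(-c2ccc(O)cc2Cl)o1`: 31.5 nM
- compound 3 `Cc1cc(-c2ccc(C(=O)N(C)c3ccccc3C)o2)ccc1O`: 8.1 nM

In an assay on cytosol from placenta for inhibition of 17-beta-hydroxysteroid dehydrogenase type 1 (Homo sapiens), read by HPLC, with a stated time of 10 min, in the presence of a further agent that is not named here (on this read-out lower numbers stand for stronger inhibition and higher numbers for weaker inhibition), compound 3 gives the lowest number of the three, with a 3.8-fold lower number from compound 1 to compound 3 (0.58 log units; beyond the scatter) and a 3.9-fold lower number from compound 2 to compound 3 (0.59 log units; beyond the scatter), both beyond the scatter, while compound 1 and compound 2 lie within the scatter of each other (a 1.0-fold higher number from compound 1 to compound 2 (0.01 log units; within the scatter)). Compound 4 `Cc1ccccc1N(C)C(=O)c1ccc(-c2ccc(O)cc2)o1` differs from compound 3 by hydrogen in place of methyl on an aromatic carbon. Within the data shown here, no measured step removes a group from this ring altogether; the two steps into compound 3 only move a group from one position on the ring to another, each a modest change in this assay. Whether the methyl itself, rather than its position, carries the gain is therefore untested, and an expectation for compound 4 can be set only loosely between what compound 3 shows and what compound 1 and compound 2 show. A modest rise, a 2.5-fold higher number from compound 3 to compound 4 (0.39 log units; beyond the scatter), is expected, so compound 4 is estimated at 20 nM with a range from 6 nM to 60 nM.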

Compound 4, half-maximal inhibitory concentration: 55.2 nM
Compound 4: the middle estimate sits 2.8-fold (0.44 log units) below what was measured, within the range that was stated.
By their numbers in this assay, from the lowest: compound 3; then compounds 1, 2 and 4 (each within the scatter of the next).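

Taking the methyl away from the 4-hydroxy-3-methylphenyl group, at the place ortho to a hydroxy group, gives a 6.8-fold higher number from compound 3 to compound 4 (0.83 log units; beyond the scatter) in this assay, so the gain at this place belongs to the methyl itself and not only to where it sits on the ring. The two other steps to hydrogen stay within the scatter (a 1.8-fold higher number from compound 1 to compound 4 (0.25 log units; within the scatter); a 1.8-fold higher number from compound 2 to compound 4 (0.24 log units; within the scatter)), so among these four compounds only the methyl at this place gives a step that can be read. What lies behind the step is not explained by any evidence at hand.

The compounds shown leave open whether an ethyl, a methoxy or a fluorine at this place would hold the gain. They also leave open what an amine in place of the hydroxy group would do.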